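Replacing 4-chlorophenyl with 6-aminopyridin-3-yl on compound 2

The source may report more compounds than this note shows. Statements on the series, on what has been measured and on what is new or still open speak of the compounds shown alone.

Two measured compounds share one core and differ only in the aromatic group attached to one carbon of the five-membered ring. Compound 1 `Cc1ccccc1-c1nnc(SCCn2c([N+](=O)[O-])cnc2C)o1` carries a 2-methylphenyl group; in a functional assay on HepG2 cells (Homo sapiens) for cytotoxicity, read by MTT assay, with a stated time of 48 h (on this read-out lower numbers stand for stronger inhibition and higher numbers for weaker inhibition), compound 1 gives 5100 nM. Compound 2 `Cc1ncc([N+](=O)[O-])n1CCSc1nnc(-c2ccc(Cl)cc2)o1` carries a 4-chlorophenyl group in the same place, and in this assay compound 2 gives 7800 nM. The step of a 1.5-fold higher number from compound 1 to compound 2 (0.18 log units; within the scatter) stays within the scatter, so these two numbers cannot be told apart with confidence. Of the two numbers shown, the one for compound 2 is the higher, with compound 1 the only neighbour.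

Compound 3 `Cc1ncc([N+](=O)[O-])n1CCSc1nnc(-c2ccc(N)nc2)o1` has not been measured. It differs from compound 2 in one place: 6-aminopyridin-3-yl in place of 4-chlorophenyl on an aromatic carbon. Going by the values given here, no measured step covers this exchange; the only step available swaps one aromatic group for another at this same place and lies within the scatter. On that basis the expected step is a 1.2-fold higher number from compound 2 to compound 3 (0.06 log units; within the scatter), meaning no change beyond the scatter is anticipated. Compound 3 is therefore estimated at 9000 nM, with a range from 3500 nM to 25000 nM.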

Compound 3, half-maximal inhibitory concentration: 9400 nM
The estimate for compound 3 lay 1.0-fold (0.02 log units) below the measured number; the range from low to high includes it.
By their numbers in this assay, from the lowest: compounds 1, 2 and 3 (each within the scatter of the next).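

In this assay, 6-aminopyridin-3-yl brings a ring nitrogen, an amino group, 1 hydrogen-bond donor and 2 hydrogen-bond acceptors to a place where 4-chlorophenyl has 0 of either, yet the result is only a 1.2-fold higher number from compound 2 to compound 3 (0.08 log units; within the scatter). The widest gap among the three compounds, a 1.8-fold higher number from compound 1 to compound 3 (0.27 log units; within the scatter), is also inside the scatter, so this carbon of the shared core has now held a carbon-only ring and a ring with a hetero atom with no difference that can be told apart in this cell assay. Nothing available explains why these numbers stay so close together.

Going by these compounds, all three compounds carry a six-membered aromatic ring at this carbon, so it remains open whether the numbers would also stay together with a small methyl group, a saturated ring such as piperidine, or a ring bearing a carboxylic acid. The compounds also share the rest of the core, which leaves open what a longer chain within it would do to the number in this assay.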